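A few compounds are considered here, and "the series" means these few. Any claim that something is new, unique, unknown or untested is made for them only; others in the source may bear on it.

Compound 3 `Oc1cc(C(F)(F)F)ccc1-c1nc(-c2ccccc2O)n(-c2cccc(F)c2)n1` gives 87.7% in a functional assay on PC-12 cells (Rattus norvegicus) for cytotoxicity, read by MTT assay, with stated times of 2 h and 24 h, tested at 5 uM (a lower number here means a weaker effect, a higher number a stronger effect of the compound at the concentration tested), the lowest of the three numbers shown, though within the scatter of compound 2 `Oc1cc(C(F)(F)F)ccc1-c1nc(-c2ccccc2O)n(-c2ccc(C(F)(F)F)cc2)n1` at 90.5% and of compound 1 `CCc1ccc(-n2nc(-c3ccc(C(F)(F)F)cc3O)nc2-c2ccccc2O)cc1` at 95.4%. The move to compound 4 `COc1cccc(-n2nc(-c3ccc(C(F)(F)F)cc3O)nc2-c2ccccc2O)c1` is methoxy in place of fluoro on an aromatic carbon. Among the compounds with values here, the steps that bear on the group on the aromatic nitrogen, a number 7.7 percentage points lower from compound 1 to compound 3 (within the scatter) and a number 2.8 percentage points lower from compound 2 to compound 3 (within the scatter), both stayed within the scatter, as did a number 4.9 percentage points lower from compound 1 to compound 2 (within the scatter) elsewhere on the shared core. Within the data shown here, no measured pair swaps fluoro for methoxy, so the next step is expected to stay within the scatter, a number 1.7 percentage points lower from compound 3 to compound 4 (within the scatter). Compound 4 is therefore estimated at 86% in this assay, with a range from 76% to 94%.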

Compound 4, a percentage reported as activity, at one concentration (the size of the read-out at that concentration, not a potency): 96.8%
Compound 4: middle estimate off by 10.8 percentage points, on the low side; measured number above the stated range.
By their numbers in this assay, from the lowest: compounds 3, 2, 1 and 4 (each within the scatter of the next).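

Methoxy in place of fluoro, the first change shown on this aromatic carbon, gives a number 9.1 percentage points higher from compound 3 to compound 4 (within the scatter) in this assay and adds a hydrogen-bond acceptor without a step beyond the scatter. Against the other groups on the aromatic nitrogen, a number 6.3 percentage points higher from compound 2 to compound 4 (within the scatter) and a number 1.4 percentage points higher from compound 1 to compound 4 (within the scatter) show that 3-methoxyphenyl also cannot be separated from 4-(trifluoromethyl)phenyl or 4-ethylphenyl. No supporting data bear on these steps.

As far as these compounds go, whether an amine or a carboxylic acid on this aromatic carbon would give a step beyond the scatter stays open. The same holds for a longer chain such as butoxy.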